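Series notes: aryl ether substituent swap, compound 4

The compounds below may be only part of what the source reports. "The series", "measured", "known", "first", "only" and "open" are said of these compounds alone.

Measured so far, in a functional assay on CHO cells for agonist activity at prostaglandin E2 receptor EP2 subtype (Homo sapiens), read by HTRF and cAMP accumulation, with a stated time of 30 min; on this read-out higher numbers stand for an effect only at larger amounts of compound and lower numbers for an effect already at smaller amounts:
compound 1 `O=C(O)c1csc([C@H]2CC[C@@H]3[C@@H](/C=C/COc4ccccc4)[C@H](O)C[C@@H]3O2)n1` — 3.8 nM
compound 2 `O=C(O)c1csc([C@H]2CC[C@@H]3[C@@H](COc4ccc(OC(F)(F)F)cc4)[C@H](O)C[C@@H]3O2)n1` — 14 nM
compound 3 `O=C(O)c1csc([C@H]2CC[C@@H]3[C@@H](/C=C/CCCOc4ccccc4)[C@H](O)C[C@@H]3O2)n1` — 13 nM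

Compound 2 gives the highest of the three numbers; compound 3 stands within the scatter of it, compound 1 beyond it. Compound 4 `Cc1ccc(OC[C@@H]2[C@H]3CC[C@H](c4nc(C(=O)O)cs4)O[C@H]3C[C@H]2O)cc1` differs from compound 2 by methyl in place of trifluoromethoxy on an aromatic carbon. For the measured compounds named here, the single measured step, a 3.4-fold higher number from compound 1 to compound 3 (0.53 log units; beyond the scatter), alters the chain between the core and the aryl ether and says nothing about a substituent on the aromatic ring itself, so no measured step bears on this change. With no guidance from the series, the expected step of a 1.2-fold lower number from compound 2 to compound 4 (0.07 log units; within the scatter) is none beyond the scatter, in either direction. Compound 4 is therefore estimated at 12 nM in this assay, with a range of 4 nM to 40 nM.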

Compound 4, half-maximal effective concentration: 27 nM
The estimate for compound 4 lay 2.3-fold (0.35 log units) below the measured number; measured number inside the range.
By their numbers in this assay, from the lowest: compound 1; then compounds 3, 2 and 4 (each within the scatter of the next, the first and the last beyond it).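

For the compounds shown here, at the aromatic carbon para to a large group, methyl in place of trifluoromethoxy gives a 1.9-fold higher number from compound 2 to compound 4 (0.29 log units; within the scatter) in this assay and is the only measured substituent change on the aromatic ring. Going by these compounds alone, the loss of 5 heavy atoms and the gain of 1 therefore produces no step separable from the scatter, so this position accepts both groups on this read-out. Nothing available explains the result.

Going by these compounds, whether chlorine or a nitrile at this carbon would move the number beyond the scatter remains open. Also open, on these data alone, is how these substituents behave with the chain of compound 1.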